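The source may hold more compounds than are shown below. What is called first, only, known or untested is meant among the compounds shown, and "the series" means these compounds.

Of the compounds shown here, three built on one shared core have so far been measured in a functional assay on HT-29 cells (Homo sapiens) for cytotoxicity, read by MTT assay, with a stated time of 72 h; a lower number here means a stronger inhibitor, a higher number a weaker inhibitor. Compound 1 `Cc1c(/N=C/c2ccc(N(C)C)cc2)c(=O)n(-c2ccccc2)n1C` gives 331000000 nM. Compound 2 `COc1ccc(/C=N/c2c(C)n(C)n(-c3ccccc3)c2=O)cc1` gives 589000000 nM, and the step of a 1.8-fold higher number from compound 1 to compound 2 (0.25 log units; within the scatter) stays within the scatter. Compound 3 `Cc1c(/N=C/c2cccc(O)c2)c(=O)n(-c2ccccc2)n1C` gives 166000000 nM, the step of a 3.5-fold lower number from compound 2 to compound 3 (0.55 log units; beyond the scatter) being the only one of the set that reaches beyond the scatter. Compound 3 thus carries the lowest number of the three, but its gap to compound 1 lies within the scatter, and only its gap to compound 2 lies beyond it.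

Compound 4 `COc1cccc(/C=N/c2c(C)n(C)n(-c3ccccc3)c2=O)c1` differs from compound 3 by methyl in place of hydrogen on an oxygen on an aromatic ring. Within the data shown here, no measured step isolates this change. The step of a 1.8-fold higher number from compound 1 to compound 2 (0.25 log units; within the scatter) brought in a methoxy group and stayed within the scatter, while the step of a 3.5-fold lower number from compound 2 to compound 3 (0.55 log units; beyond the scatter) changed both the oxygen substituent and its place on the ring at once. Neither step shows the methyl on its own. The expected step is therefore a 1.5-fold higher number from compound 3 to compound 4 (0.18 log units; within the scatter), that is, nothing beyond the scatter, leaning slightly toward a higher number. For compound 4 the estimate in this assay is 250000000 nM, with a range from 100000000 nM to 600000000 nM.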

Compound 4, half-maximal inhibitory concentration: 155000000 nM
Compound 4: the middle estimate sits 1.6-fold (0.21 log units) above what was measured, and the stated range covers the measured number.
By their numbers in this assay, from the lowest: compounds 4, 3, 1 and 2 (each within the scatter of the next, the first and the last beyond it).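

In this assay, among these compounds, methyl in place of hydrogen on the oxygen gives a 1.1-fold lower number from compound 3 to compound 4 (0.03 log units; within the scatter), so hydroxy and methoxy on this aromatic ring cannot be told apart here, a comparison that no earlier pair offered. The step of a 3.8-fold lower number from compound 2 to compound 4 (0.58 log units; beyond the scatter) keeps the methoxy group and alters only where it sits, 3-methoxyphenyl in place of 4-methoxyphenyl, and it reaches beyond the scatter; the place of the group therefore matters in this pair, whereas the earlier step to compound 3 had changed the oxygen substituent and its place together. Nothing at hand explains why the place of the methoxy group matters while the methyl on the oxygen shows no readable effect.

The compounds shown leave open whether a longer chain in place of the methyl on the oxygen, or an amine or a carboxylic acid in place of the whole methoxy group, would stay within the scatter of compound 3 as compound 4 does. On these data alone, the effect of place also rests on this single pair, so it remains open whether dimethylamino, the group carried by compound 1, would respond to a change of place in the same way.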